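Cinnamyl-piperidine carboxamides: aryl amide variation in HepG2 inhibition

The compounds below may be only part of what the source reports. "The series", "measured", "known", "first", "only" and "open" are said of these compounds alone.

Measured so far:
- compound 1 `CCCc1ccc(NC(=O)C2CCN(C/C=C/c3ccccc3)CC2)cc1`: 9410 nM
- compound 2 `COc1ccc(NC(=O)C2CCN(C/C=C/c3ccccc3)CC2)cc1`: 88800 nM
- compound 3 `O=C(Nc1cccc2cccnc12)C1CCN(C/C=C/c2ccccc2)CC1`: 29500 nM

All three share one core and differ only in the aryl group on the amide nitrogen. In a functional assay on HepG2 cells (Homo sapiens) for inhibition, read by MTT assay, with a stated time of 72 h (a higher number here means a weaker inhibitor, a lower number a stronger inhibitor), compound 1 gives the lowest number of the three; compound 3 sits nearer, compound 2 furthest. Going by the values given here, the one single-point step, a 9.4-fold higher number from compound 1 to compound 2 (0.97 log units; beyond the scatter), shows that exchanging the propyl for a methoxy on the aromatic carbon costs potency. Compound 3 carries a bicyclic nitrogen-containing aryl instead of the propylphenyl and gives 29500 nM, also a higher number than compound 1.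

Compound 4 `O=C(Nc1ccccn1)C1CCN(C/C=C/c2ccccc2)CC1` is not yet measured. The change from compound 1 is pyridin-2-yl in place of 4-propylphenyl on an amide-type nitrogen. Both measured departures from the propylphenyl of compound 1 gave higher numbers, and compound 4 removes the propyl entirely while bringing in a ring nitrogen, so a weaker inhibitor is expected, with a step of about a 4.3-fold higher number from compound 1 to compound 4 (0.63 log units; beyond the scatter). Compound 4 is therefore estimated at 40000 nM, within a range of 12000 nM to 130000 nM.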

Compound 4, half-maximal inhibitory concentration: 51100 nM
Compound 4: middle estimate off by 1.3-fold (0.11 log units), on the low side; the measured number falls inside the stated range.
By their numbers in this assay, from the lowest: compound 1; then compounds 3, 4 and 2 (each within the scatter of the next, the first and the last beyond it).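

Putting pyridin-2-yl in place of 4-propylphenyl in this assay gives a 5.4-fold higher number from compound 1 to compound 4 (0.73 log units; beyond the scatter), so a second group with no propyl chain also falls beyond the scatter from compound 1 at this amide-type nitrogen. Pyridin-2-yl in place of 4-methoxyphenyl gives a 1.7-fold lower number from compound 2 to compound 4 (0.24 log units; within the scatter), so this pair cannot be separated, even though the entering ring holds a hetero atom and the leaving ring holds carbon only. Nothing at hand explains the gap to the 4-propylphenyl amide.

Still open, as far as these compounds go, is whether the lower number of compound 1 tracks the propyl chain itself, which a butyl chain or an ethyl group in its place would test. Also open, from the compounds shown here alone, is whether a propyl group on the pyridin-2-yl ring would bring the number back towards that of compound 1.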